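Ethyl to propyl on a benzimidazole-type mGluR2 series

The source may report more compounds than this note shows. Statements on the series, on what has been measured and on what is new or still open speak of the compounds shown alone.

Measured so far:
compound 1, `CCn1c(CN2CCN(c3ncc(Cl)cn3)CC2)nc2ccccc21`, 158 nM
compound 2, `FC(F)(F)c1ccc(Cl)nc1N1CCN(Cc2nc3ccccc3[nH]2)CC1`, 12600 nM

Of the compounds shown here, two have been measured in an assay on CHO cells with metabotropic glutamate receptor 2 (Homo sapiens) as the target, read by FLIPR; on this read-out higher numbers stand for an effect only at larger amounts of compound and lower numbers for an effect already at smaller amounts. Going by the values given here, compound 1 has the lowest of the two numbers, giving 158 nM, while compound 2 gives 12600 nM, a gap that lies beyond the usual scatter; no single structural step links these two, so the pair shows only that the two values differ widely.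

The piece follows the step from compound 1 to compound 3, `CCCn1c(CN2CCN(c3ncc(Cl)cn3)CC2)nc2ccccc21`, which has not yet been measured in this assay. The change is small: methyl in place of hydrogen on a saturated chain carbon, two bonds along the chain from an aromatic nitrogen. Because compound 1 sits at 158 nM and the change adds only one carbon to a saturated chain, the expectation is a step of modest size, of about a 1.2-fold lower number from compound 1 to compound 3 (0.08 log units; within the scatter), which may well fall within the scatter in either direction. On that basis compound 3 is estimated to give 130 nM, within a range from 50 nM to 400 nM.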

Compound 3, half-maximal effective concentration: 794 nM
For compound 3 the middle estimate is 6.1-fold (0.79 log units) below the measured one; measured number above the stated range.
By their numbers in this assay, from the lowest: compound 1; then compound 3; then compound 2.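

Ethyl to propyl, a methyl in place of hydrogen on a saturated chain carbon, two bonds along the chain from an aromatic nitrogen, gives a 5.0-fold higher number from compound 1 to compound 3 (0.70 log units; beyond the scatter) in this assay, so this position is not indifferent to a single added carbon. Compound 1 and compound 2 differ in more than one place and could not speak for any one position, whereas here the rest of the molecule stays the same and the shift belongs to this one change, with the higher number meaning that more of compound 3 is needed for the same effect. No measurement at hand explains why the propyl chain goes with the higher number.

Two chain lengths do not make a trend, and the compounds shown leave open how a methyl on that aromatic nitrogen would read and whether a butyl chain would move the number further in the same direction. Also open, from the compounds shown here alone, is how a cyclopropylmethyl group, or an ethyl chain ending in a hydroxyl group, would compare with the ethyl of compound 1.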